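Adding a methyl to the chain of compound 3

The source may hold more compounds than are shown below. What is called first, only, known or untested is meant among the compounds shown, and "the series" means these compounds.

Measured so far in a functional assay on the whole organism for inhibition, with Brassica rapa subsp. chinensis as the target, with a stated time of 3 days, tested at 100 ppm; a lower number here means less inhibition of growth, a higher number more inhibition of growth at the concentration tested:

compound 1 `CCCCCCNC(=O)/C=C/c1ccccc1` gives 82%
compound 2 `CCC(C)NC(=O)/C=C/c1ccccc1` gives 77%
compound 3 `CCCNC(=O)/C=C/c1ccccc1` gives 63%

Compound 3 has the lowest number of the three, and both other compounds lie beyond the scatter from it. The next compound to be tested is compound 4 `CC(C)CNC(=O)/C=C/c1ccccc1`. Its difference from compound 3 is methyl in place of hydrogen on a saturated chain carbon bound to two saturated chain carbons, which in words is methyl in place of hydrogen on a saturated chain carbon bound to two saturated chain carbons.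

Within the data shown here, two measured steps bear on this change. One is a number 19 percentage points lower from compound 1 to compound 3 (beyond the scatter) with hydrogen replacing propyl, and the other is a number 14 percentage points lower from compound 2 to compound 3 (beyond the scatter) with hydrogen replacing methyl. Both are modest, and neither concerns the carbon changed here. Read in reverse, each shows a larger chain than that of compound 3 going with a higher number, so a modest upward step is expected in this assay. The estimated change is a number 11 percentage points higher from compound 3 to compound 4 (beyond the scatter) in this reading. Compound 4 is expected at 74% with an estimated range from 62% to 86% for the coming measurement.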

Compound 4, percent growth inhibition at one concentration: 78%
Estimate against measurement, compound 4: 4 percentage points below; the range from low to high includes it.
By their numbers in this assay, from the lowest: compound 3; then compounds 2, 4 and 1 (each within the scatter of the next).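

In this assay, methyl in place of hydrogen on a saturated chain carbon bound to two saturated chain carbons gives a number 15 percentage points higher from compound 3 to compound 4 (beyond the scatter) and is the first change shown at this carbon, so a branch here does register in the read-out. Isobutyl in place of sec-butyl on an amide-type nitrogen gives a number 1 percentage points higher from compound 2 to compound 4 (within the scatter) and stays within the scatter, so these two branched chains cannot be told apart. Isopropyl in place of pentyl on a saturated chain carbon bound to an amide-type nitrogen gives a number 4 percentage points lower from compound 1 to compound 4 (within the scatter) and also stays within the scatter, so compound 4 cannot be told apart from compound 1 either.

From the compounds shown here alone, whether a hydroxyl group, an amine or a longer branched chain at this carbon would keep the number at this level remains open. Nothing available explains the effect of the added methyl.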